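Benzylthio series: chloro to bromo at the aromatic ring

The source may hold more compounds than are shown below. What is called first, only, known or untested is meant among the compounds shown, and "the series" means these compounds.

Measured so far:
compound 1 `Cn1c(=O)c2c(nc(SCc3ccccc3)n2C)n(C)c1=O` — 1860 nM
compound 2 `Cn1c(=O)c2c(nc(SCc3ccc(Cl)cc3)n2C)n(C)c1=O` — 192 nM

The series is followed in an assay on isolated protein for inhibition of Amine oxidase [flavin-containing] B (Homo sapiens), read by fluorescence; on this read-out higher numbers stand for weaker inhibition and lower numbers for stronger inhibition. Compound 1 `Cn1c(=O)c2c(nc(SCc3ccccc3)n2C)n(C)c1=O` gives 1860 nM, and compound 2 `Cn1c(=O)c2c(nc(SCc3ccc(Cl)cc3)n2C)n(C)c1=O` gives 192 nM. Compound 2 stands lowest of the two numbers shown; its only neighbour is compound 1, and the step of a 9.7-fold lower number from compound 1 to compound 2 (0.99 log units; beyond the scatter) is the single measured step in the set.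

Compound 3 `Cn1c(=O)c2c(nc(SCc3ccc(Br)cc3)n2C)n(C)c1=O` differs from compound 2 by bromo in place of chloro on an aromatic carbon. For the measured compounds named here, no measured step exchanges one halogen for another. The step of a 9.7-fold lower number from compound 1 to compound 2 (0.99 log units; beyond the scatter) bears on it only indirectly: it shows that a halogen at this place on the ring gives a lower number than hydrogen. Replacing that halogen by bromo keeps the substituted ring, so a step within the scatter, or at most a slightly lower number, is expected. Compound 3 is therefore expected to give 150 nM, in the range 60 nM to 450 nM. The expected step is a 1.3-fold lower number from compound 2 to compound 3 (0.11 log units; within the scatter).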

Compound 3, half-maximal inhibitory concentration: 167 nM
Compound 3: the middle estimate sits 1.1-fold (0.05 log units) below what was measured; measured number inside the range.
By their numbers in this assay, from the lowest: compounds 3 and 2 (each within the scatter of the next); then compound 1.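

In this assay, exchanging one halogen for another on this aromatic carbon, para to a large group, gives a 1.1-fold lower number from compound 2 to compound 3 (0.06 log units; within the scatter) and so does not separate 4-chlorophenyl from 4-bromophenyl. Bromo in place of hydrogen gives an 11-fold lower number from compound 1 to compound 3 (1.05 log units; beyond the scatter) and stands beyond the scatter, so the distance from compound 1 is not tied to chloro alone but holds for both halogens shown. No measurement at hand accounts for this result.

Still open, from the compounds shown here alone, is whether a group other than a halogen at this place, such as methoxy, nitrile or trifluoromethyl, would match compound 2 and compound 3. Also open, going by these compounds, are fluoro and iodo, an amine or a carboxylic acid on the ring, and any change to the benzylthio link or the shared core.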